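The source may hold more compounds than are shown below. What is called first, only, known or untested is meant among the compounds shown, and "the series" means these compounds.

Measured compounds:
- compound 1, `O=CN1N=C(c2ccc(F)cc2)CC1c1cn(-c2ccccc2)nc1-c1ccc(Cl)c(Cl)c1`: 60.9%
- compound 2, `Fc1ccc(C2=NN(c3ccccc3)C(c3cn(-c4ccccc4)nc3-c3ccc(Cl)c(Cl)c3)C2)cc1`: 60.2%
- compound 3, `Cc1ccc(C2=NN(C=O)C(c3cn(-c4ccccc4)nc3-c3ccc(Cl)c(Cl)c3)C2)cc1`: 60.9%

All three are read in a functional assay on the whole organism (strain Wistar) for inhibition, with Rattus norvegicus as the target, read by paw edema, with stated times of 30 min and 120 min, at a dose of 50 mg/kg by the oral route; a lower number here means less inhibition, a higher number more inhibition at the dose given (going by the name of the read-out). The three numbers lie within the scatter of one another, so no order among them is claimed. Compound 1 and compound 3 share the formyl group and differ only in the change (methyl in place of fluoro on an aromatic carbon); the step of no change at the digits printed from compound 1 to compound 3 (within the scatter) is flat. Compound 1 and compound 2 differ in the change (phenyl in place of formyl on an amine nitrogen in a ring), and the step of a number 0.7 percentage points lower from compound 1 to compound 2 (within the scatter) is likewise within the scatter.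

The unmeasured compound 4, `Cc1ccc(C2=NN(c3ccccc3)C(c3cn(-c4ccccc4)nc3-c3ccc(Cl)c(Cl)c3)C2)cc1`, carries the change phenyl in place of formyl on an amine nitrogen in a ring relative to compound 3. This is the same kind of change as that from compound 1 to compound 2: formyl leaves and phenyl enters on the amine nitrogen in the ring, next to the ring nitrogen and next to the ring atom that bears a large group. What differs around the place is the group two ring bonds away: a 4-methylphenyl group in compound 3 and compound 4, a 4-fluorophenyl group in compound 1 and compound 2. That difference between the two cores is the one counted under (methyl in place of fluoro on an aromatic carbon).

Among the compounds with values here, with only one measured instance of the change, the expectation for compound 4 rests on the step from compound 1 to compound 2, a number 0.7 percentage points lower from compound 1 to compound 2 (within the scatter), and on the flat step no change at the digits printed from compound 1 to compound 3 (within the scatter); the expected step is a number 0.7 percentage points lower from compound 3 to compound 4 (within the scatter). Compound 4 is accordingly estimated at 60.2% in this assay, with a likely range from 50% to 70%.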

Compound 4, a percentage reported as inhibition, in the whole organism at one dose (the size of the read-out at that dose, not a potency): 62.5%
Compound 4: middle estimate off by 2.3 percentage points, on the low side; low and high end bracket the measured number.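

In this assay, phenyl in place of formyl on the amine nitrogen in the ring gives a number 1.6 percentage points higher from compound 3 to compound 4 (within the scatter), and the change reads the same on the core of compound 1 and the core of compound 3: the same change on two cores in this assay, a number 0.7 percentage points lower (within the scatter) from compound 1 to compound 2 and a number 1.6 percentage points higher (within the scatter) from compound 3 to compound 4, 2.3 percentage points apart, within the scatter of two such steps. Methyl in place of fluoro on an aromatic carbon behaves alike, with a number 2.3 percentage points higher from compound 2 to compound 4 (within the scatter) set beside the earlier flat step: the same change on two cores in this assay, no change at the digits printed (within the scatter) from compound 1 to compound 3 and a number 2.3 percentage points higher (within the scatter) from compound 2 to compound 4, 2.3 percentage points apart, within the scatter of two such steps. This agreement is between steps that are each within the scatter, so it shows that neither change has a detectable effect on these two cores, but it does not show that an effect of either change would carry from one core to another, and a read-out at one dose says nothing about potency.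

The compounds shown leave open whether a different group on the amine nitrogen in the ring, such as acetyl, benzyl or a chain ending in an amine, would move the inhibition of paw edema away from this level. They also leave open whether methoxy or a carboxylic acid in place of the methyl or the fluoro would do so, and whether any such step would hold on both cores.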